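From quinolin-3-yl to quinolin-6-yl on the shared core

The source may report more compounds than this note shows. Statements on the series, on what has been measured and on what is new or still open speak of the compounds shown alone.

In a functional assay on DU-145 cells (Homo sapiens) for cytotoxicity, read by MTT assay, with a stated time of 48 h (a higher number here means a weaker inhibitor, a lower number a stronger inhibitor), compound 3 (`O=C(/C=C\Nc1cnc2ccccc2c1)c1c(-c2ccc(Cl)cc2)nc2ccccn12`) gives 4170 nM. That places it in the middle of the three numbers, since compound 1 (`COc1cc(N/C=C\C(=O)c2c(-c3ccc(Cl)cc3)nc3ccccn23)cc(OC)c1`) gives 12000 nM and compound 2 (`O=C(/C=C\Nc1ccc2[nH]ccc2c1)c1c(-c2ccc(Cl)cc2)nc2ccccn12`) gives 1290 nM. Compound 4 (`O=C(/C=C\Nc1ccc2ncccc2c1)c1c(-c2ccc(Cl)cc2)nc2ccccn12`) keeps the shared core and changes one group on an amine nitrogen, with quinolin-6-yl in place of quinolin-3-yl on an amine nitrogen. The two compounds have the same atoms, joined differently.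

Among the compounds with values here, no measured pair shows this exact kind of change. The closest evidence comes from three swaps at the same place: a 9.3-fold lower number from compound 1 to compound 2 (0.97 log units; beyond the scatter), a 2.9-fold lower number from compound 1 to compound 3 (0.46 log units; beyond the scatter) and a 3.2-fold higher number from compound 2 to compound 3 (0.51 log units; beyond the scatter). All three steps are modest, even though they exchange differently named groups. A shift within one quinoline is therefore expected to be no larger, and the data give no clear direction, so no step beyond the scatter is expected. The estimated step is a 1.4-fold lower number from compound 3 to compound 4 (0.14 log units; within the scatter). For compound 4 the estimated value is 3000 nM, with an expected range from 1000 nM to 9000 nM.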

Compound 4, half-maximal inhibitory concentration: 13600 nM
For compound 4 the middle estimate is 4.5-fold (0.66 log units) below the measured one, and the stated range ends below it.
By their numbers in this assay, from the lowest: compound 2; then compound 3; then compounds 1 and 4 (each within the scatter of the next).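

In this assay the attachment point of the quinoline counts on its own: quinolin-6-yl in place of quinolin-3-yl on the amine nitrogen gives a 3.3-fold higher number from compound 3 to compound 4 (0.51 log units; beyond the scatter) with the same atoms throughout. Against 1H-indol-5-yl the same group gives an 11-fold higher number from compound 2 to compound 4 (1.02 log units; beyond the scatter) and that step is large. Against 3,5-dimethoxyphenyl it gives a 1.1-fold higher number from compound 1 to compound 4 (0.05 log units; within the scatter) and so a quinoline on this nitrogen does not in itself lower the number from that of compound 1: compound 3 does, compound 4 does not.

No measurement shown offers a reason for the gap between the two quinolines. Also open, on these data alone, is whether quinolin-5-yl or quinolin-7-yl would sit closer to quinolin-3-yl or to quinolin-6-yl, and whether 1H-indol-6-yl would hold the lower number of compound 2.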